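The source may hold more compounds than are shown below. What is called first, only, known or untested is meant among the compounds shown, and "the series" means these compounds.

Compound 1 `CCCNC(=O)COc1ccc2cc(C(O)(C(F)(F)F)C(F)(F)F)c(O)cc2c1` was tested in an assay on isolated protein for inhibition of tyrosine-protein phosphatase non-receptor type 13 (Homo sapiens), read by spectrophotometry (on this read-out lower numbers stand for stronger inhibition and higher numbers for weaker inhibition), where compound 1 gives only > 20000 nM, a limit of the assay rather than a measured number. Compound 2 `Oc1c(C(O)(C(F)(F)F)C(F)(F)F)ccc2ccccc12` is the other compound examined so far; in this assay compound 2 likewise gives only a limit, > 500000 nM. Both results therefore sit at limits, the limit of > 20000 nM in this assay, at which 1 of the 2 values shown sits, and (the limit of > 500000 nM in this assay, at which 1 of the 2 values shown sits), so compound 1 stands at a point where no potency can be read, and nothing is known about how large a shift any single alteration brings. Compound 3 `O=C(COc1ccc2cc(C(O)(C(F)(F)F)C(F)(F)F)c(O)cc2c1)Nc1ccccc1` differs from compound 1 in one place: phenyl in place of propyl on an amide-type nitrogen. For the measured compounds named here, with no measured step to lean on, the expectation is that this change brings no shift beyond the scatter, and the estimated step of a number no higher from compound 1 to compound 3 (the limit leaves the size open) reflects that. Compound 3 is therefore expected to give about 20000 nM, within a range from 5000 nM to 100000 nM, most likely again reported only as a limit.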

Compound 3, half-maximal inhibitory concentration: > 20000 nM
Compound 3 gave a limit, no number; the forecaster's own chance of this, stated with the estimate: 70%; the middle value lies on the limit itself.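

In this assay compound 1 and compound 3 each give only a limit rather than a measured number, so the size of the change from propyl to phenyl cannot be read. The compounds shown leave open how strongly any of them inhibits the enzyme and how much any single change shifts that inhibition.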